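The source may report more compounds than this note shows. Statements on the series, on what has been measured and on what is new or still open speak of the compounds shown alone.

Of the compounds shown here, three built on one shared core have been tested in an assay on isolated protein for binding affinity to cysteinyl leukotriene receptor 1 (Cavia porcellus); a lower number here means a stronger inhibitor, a higher number a weaker inhibitor. Compound 1 `COc1cc(C(=O)NS(=O)(=O)c2ccccc2C)ccc1Cc1cn(C(F)F)c2ccc(NC(=O)OC3CCCC3)cc12` gives 1 nM. Compound 2 `COc1cc(C(=O)NS(=O)(=O)c2ccccc2C)ccc1Cc1cn(C=O)c2ccc(NC(=O)OC3CCCC3)cc12` gives 1 nM. Compound 3 `CCN(CC)C(=O)n1cc(Cc2ccc(C(=O)NS(=O)(=O)c3ccccc3C)cc2OC)c2cc(NC(=O)OC3CCCC3)ccc21` gives 0.5 nM, the lowest of the three numbers, though it is not separated from the other two beyond the scatter: a 2.0-fold lower number from compound 1 to compound 3 (0.30 log units; within the scatter) and a 2.0-fold lower number from compound 2 to compound 3 (0.30 log units; within the scatter) are each no larger than repeated measurements of one compound usually show.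

Compound 4 `COc1cc(C(=O)NS(=O)(=O)c2ccccc2C)ccc1Cc1cn(C(=O)NCCCc2ccccc2)c2ccc(NC(=O)OC3CCCC3)cc12` has not yet been measured. It differs from compound 3 in one place: (3-phenylpropyl)amino in place of diethylamino on a carbonyl carbon. The step that bears most directly on this change is a 2.0-fold lower number from compound 2 to compound 3 (0.30 log units; within the scatter), which also exchanged the group on that carbonyl carbon and did not move the number beyond the scatter. The steps of no change at the digits printed from compound 1 to compound 2 (within the scatter) and a 2.0-fold lower number from compound 1 to compound 3 (0.30 log units; within the scatter) replaced the whole group on the aromatic nitrogen, again without a step beyond the scatter. Three changes at the aromatic nitrogen or on the carbonyl carbon attached to it have thus left the number essentially in place, so no step beyond the scatter is expected in this assay for compound 4, in either direction. The step expected in this assay is a 1.4-fold higher number from compound 3 to compound 4 (0.15 log units; within the scatter). On that basis compound 4 is estimated at 0.7 nM, with a range from 0.2 nM to 2.5 nM.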

Compound 4, half-maximal inhibitory concentration: 0.5 nM
The estimate for compound 4 lay 1.4-fold (0.15 log units) above the measured number; low and high end bracket the measured number.
By their numbers in this assay, from the lowest: compounds 3, 4, 1 and 2 (each within the scatter of the next).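

In this assay, replacing diethylamino with (3-phenylpropyl)amino on the carbonyl carbon gives no change at the digits printed from compound 3 to compound 4 (within the scatter) even though the change brings in a much larger group: 10 heavy atoms with a six-membered aromatic ring and 1 hydrogen-bond donor, where the group it replaces has 5 heavy atoms, no ring and no donor. Compound 4 also shows a 2.0-fold lower number from compound 2 to compound 4 (0.30 log units; within the scatter) and a 2.0-fold lower number from compound 1 to compound 4 (0.30 log units; within the scatter) so, across all four compounds, the aromatic nitrogen has carried groups from difluoromethyl to (3-phenylpropyl)carbamoyl with no step beyond the scatter. No accompanying measurement shows how this position accommodates such different groups.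

On these data alone, whether a carboxylic acid or an amine at the end of the chain, or a chain longer than 3-phenylpropyl, would keep the number in this range remains open. Also open, as far as these compounds go, is whether the amide hydrogen of compound 4 matters, a question that an N-methyl version of the same group could answer.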